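The source may report more compounds than this note shows. Statements on the series, on what has been measured and on what is new or still open speak of the compounds shown alone.

Compound 1 `Cc1nc(Nc2ccc3sc(C(=O)Nc4c(C)cccc4Cl)cc3c2)cc(N2CCCCC2)n1` was examined in a functional assay on U-937 cells (Homo sapiens) for cytotoxicity, read by MTT assay and WST assay, with a stated time of 72 h (on this read-out lower numbers stand for stronger inhibition and higher numbers for weaker inhibition), where compound 1 gives 20000 nM. For the measured compounds named here, this is the higher of the two numbers measured so far; compound 2 `CCN(CC)CCCOc1cc2ncnc(Nc3ccc4sc(C(=O)Nc5c(C)cccc5Cl)cc4c3)c2cc1OC` gives 4010 nM in this assay, and the gap between the two lies beyond the usual scatter of repeated measurements. Compound 3 `Cc1nc(Nc2ccc3sc(C(=O)Nc4c(C)cccc4Cl)cc3c2)cc(N2CCN(C)CC2)n1` has not yet been measured. It differs from compound 1 in a single place: 4-methylpiperazin-1-yl in place of piperidin-1-yl on an aromatic carbon. Going by the values given here, no measured pair shows this particular change, so its effect is open. The rest of the shared core is unchanged. In this assay the expected result is a 1.7-fold lower number from compound 1 to compound 3 (0.22 log units; within the scatter), a modest move toward a lower number that may well stay within the usual scatter. Compound 3 is therefore estimated at 12000 nM, with a range from 4000 nM to 40000 nM.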

Compound 3, half-maximal inhibitory concentration: 15000 nM
Estimate against measurement, compound 3: 1.3-fold (0.10 log units) below; the measured number falls inside the stated range.
By their numbers in this assay, from the lowest: compound 2; then compounds 3 and 1 (each within the scatter of the next).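

In this assay, placing 4-methylpiperazin-1-yl instead of piperidin-1-yl on this aromatic carbon gives a 1.3-fold lower number from compound 1 to compound 3 (0.12 log units; within the scatter) and so yields no readable difference between the two compounds. For the compounds shown here, at this place, then, a six-membered non-aromatic ring with 2 hetero atoms and one with 1 hetero atom cannot be told apart in this read-out, which the earlier compounds could not show because they offered no such pair. Nothing measured here offers an explanation for this result.

The compounds shown leave open whether a morpholin-4-yl ring, an open-chain amine such as diethylamino, or a carboxylic acid at this place would move the number beyond the scatter. They also leave open whether the same exchange would behave alike on a different core.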